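Trading 3-chlorophenyl for 4-methylphenyl on a shared core

The source may hold more compounds than are shown below. What is called first, only, known or untested is meant among the compounds shown, and "the series" means these compounds.

In a functional assay on MCF7 cells (Homo sapiens) for antiproliferative activity, read by MTT assay, with a stated time of 48 h (on this read-out lower numbers stand for stronger inhibition and higher numbers for weaker inhibition), compound 1 `COc1ccc(-c2nn(-c3ccccc3)cc2C(Nc2nc3ccccc3s2)c2c(O)ccc3ccccc23)cc1` gives 17500 nM. Compound 2 `Oc1ccc2ccccc2c1C(Nc1nc2ccccc2s1)c1cn(-c2ccccc2)nc1-c1cccc(Cl)c1` gives 20700 nM, which puts it level with compound 1 once the usual scatter of repeat measurements is allowed for. Compound 3 `Cc1ccc(-c2nn(-c3ccccc3)cc2C(Nc2nc3ccccc3s2)c2c(O)ccc3ccccc23)cc1` keeps the core of compound 2 and carries 4-methylphenyl in place of 3-chlorophenyl on an aromatic carbon of a five-membered aromatic ring with 2 nitrogen: 4-methylphenyl in place of 3-chlorophenyl on an aromatic carbon. Among the measured compounds shown here, only one measured step bears on this change, since it altered the group on that same carbon, putting 3-chlorophenyl in place of 4-methoxyphenyl: a 1.2-fold higher number from compound 1 to compound 2 (0.07 log units; within the scatter). For the measured compounds named here, with one such step as the only guide, no shift beyond the scatter is expected in this assay. The estimated step is a 1.1-fold lower number from compound 2 to compound 3 (0.04 log units; within the scatter). For compound 3 the expected value is 19000 nM, with an estimated range from 9000 nM to 40000 nM.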

Compound 3, half-maximal inhibitory concentration: 13100 nM
Compound 3: middle estimate off by 1.5-fold (0.16 log units), on the high side; the range from low to high includes it.
By their numbers in this assay, from the lowest: compounds 3, 1 and 2 (each within the scatter of the next).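

In this assay, the swap at this carbon of the five-membered ring shows no change beyond the scatter (a 1.6-fold lower number from compound 2 to compound 3 (0.20 log units; within the scatter)). Replacing the methoxy of compound 1 with methyl also stays within it (a 1.3-fold lower number from compound 1 to compound 3 (0.13 log units; within the scatter)). Compounds 1, 2 and 3 therefore stand level, so at this position a chlorine, a methoxy or a methyl on the phenyl ring, at the two ring positions shown, makes no readable difference. Nothing measured here offers a reason for this evenness.

All three groups at this carbon are substituted phenyl rings, so these compounds cannot show how far that tolerance extends. From the compounds shown here alone, it remains open whether an amine or a carboxylic acid on the phenyl ring, or a short alkyl chain replacing the ring, would move the number beyond the scatter.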